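The source may report more compounds than this note shows. Statements on the series, on what has been measured and on what is new or still open speak of the compounds shown alone.

Compound 1 `CC(NC(=O)/C=C/c1ccc(NC(=O)Nc2ccc(Cl)c(C(F)(F)F)c2)cc1)c1ccccc1` stands lowest of the three numbers in a functional assay on HepG2 cells (Homo sapiens) for inhibition, read by MTT assay, with a stated time of 120 h (a lower number here means a stronger inhibitor, a higher number a weaker inhibitor), where compound 1 gives 12200 nM. Compound 2 `CNC(=O)/C=C/c1ccc(NC(=O)Nc2ccc(Cl)c(C(F)(F)F)c2)cc1` gives 20400 nM, and compound 3 `CC1CN(C(=O)/C=C/c2ccc(NC(=O)Nc3ccc(Cl)c(C(F)(F)F)c3)cc2)CC(C)O1` gives 45900 nM. The step of a 1.7-fold higher number from compound 1 to compound 2 (0.22 log units; within the scatter) lies within the scatter, whereas a 3.8-fold higher number from compound 1 to compound 3 (0.58 log units; beyond the scatter) and a 2.3-fold higher number from compound 2 to compound 3 (0.35 log units; beyond the scatter) are modest. Compound 4 `CC(NC(=O)/C=C/c1ccc(NC(=O)Nc2cc(C(F)(F)F)ccc2Cl)cc1)c1ccccc1` is made from compound 1 by the change (2-chloro-5-(trifluoromethyl)phenyl in place of 4-chloro-3-(trifluoromethyl)phenyl on an amide-type nitrogen), which leaves the amide end untouched. Going by the values given here, none of the measured steps bears on this change, since all three alter only the carbonyl substituent. Among the compounds with values here, with no step that touches the aryl urea, the expectation is a step of no more than modest size in either direction, a 1.2-fold higher number from compound 1 to compound 4 (0.09 log units; within the scatter), for compound 4. Compound 4 is therefore estimated at 15000 nM, with a range from 5000 nM to 50000 nM.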

Compound 4, half-maximal inhibitory concentration: 35900 nM
For compound 4 the middle estimate is 2.4-fold (0.38 log units) below the measured one; the measured number falls inside the stated range.
By their numbers in this assay, from the lowest: compounds 1, 2, 4 and 3 (each within the scatter of the next, the first and the last beyond it).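

The aryl urea end now has a reading of its own: in this assay, 2-chloro-5-(trifluoromethyl)phenyl in place of 4-chloro-3-(trifluoromethyl)phenyl on the amide-type nitrogen gives a 2.9-fold higher number from compound 1 to compound 4 (0.47 log units; beyond the scatter) with the heavy-atom count unchanged. Going by these compounds alone, the earlier compounds varied only the carbonyl substituent, so this is the first sign that the arrangement of chlorine and trifluoromethyl on this phenyl also moves the number. No supporting measurement speaks to why this step occurs.

Open, on these data alone, is whether the same exchange gives a similar step with the methylamide of compound 2 or the 2,6-dimethylmorpholin-4-yl amide of compound 3. Also open, as far as these compounds go, is how this position responds when a nitrile or methoxy group replaces the chlorine.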